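Acetyl to Ethoxycarbonyl on a Weakly Cytotoxic Thiadiazole Imine

The compounds below may be only part of what the source reports. "The series", "measured", "known", "first", "only" and "open" are said of these compounds alone.

Compound 1 `CC(=O)c1nn(-c2ccccc2)/c(=N/c2nc(-c3c(C)n(C)n(-c4ccccc4)c3=O)cs2)s1`: 67100 nM
Compound 2 `CC(=O)c1nn(-c2ccc(C)cc2)/c(=N/c2nc(-c3c(C)n(C)n(-c4ccccc4)c3=O)cs2)s1`: 31700 nM
Compound 3 `CC(=O)c1nn(-c2ccc([N+](=O)[O-])cc2)/c(=N/c2nc(-c3c(C)n(C)n(-c4ccccc4)c3=O)cs2)s1`: > 100000 nM

These three compounds share one core and differ only in the group on the phenyl ring attached to the thiadiazole. In a functional assay on HepG2 cells (Homo sapiens) for cytotoxicity, read by sulforhodamine B assay, with a stated time of 72 h (a higher number here means a weaker inhibitor, a lower number a stronger inhibitor), compound 1 gives 67100 nM. Compound 2, carrying a methyl there, gives 31700 nM, a step of a 2.1-fold lower number from compound 1 to compound 2 (0.33 log units; beyond the scatter). Compound 3 carries a nitro group and is reported only as a limit, > 100000 nM, so it sits at the limit of > 100000 nM in this assay, at which 1 of the 3 values shown sits. The steps of an at least 1.4-fold higher number from compound 1 to compound 3 (0.17 log units; that floor lies within the scatter) and an at least 3.1-fold higher number from compound 2 to compound 3 (0.49 log units; beyond the scatter) are therefore floors, not exact numbers.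

Compound 4 `CCOC(=O)c1nn(-c2ccc([N+](=O)[O-])cc2)/c(=N/c2nc(-c3c(C)n(C)n(-c4ccccc4)c3=O)cs2)s1` keeps the nitro group of compound 3 and changes the other end: ethoxy in place of methyl on a carbonyl carbon. Within the data shown here, none of the measured steps touches this carbonyl group, so no measured step bears on it directly; all that is known is that compound 3 is the weakest of the three and already at the limit of this assay. The expectation is therefore a step of a number no higher from compound 3 to compound 4 (the limit leaves the size open), essentially none beyond the scatter, with compound 4 estimated at 100000 nM (range 40000 nM to 250000 nM), most likely again reported only as a limit.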

Compound 4, half-maximal inhibitory concentration: 8110 nM
Beside the measured number, compound 4's estimate is 12-fold (1.09 log units) above it; the whole stated range lies above it.
By their numbers in this assay, from the lowest: compound 4; then compound 2; then compound 1. At a limit, above all of these: compound 3.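

The earlier compounds shown here changed only the group on the phenyl ring, so they said nothing about the carbonyl end of the molecule. In this assay, changing acetyl to ethoxycarbonyl gives an at least 12-fold lower number from compound 3 to compound 4 (1.09 log units; beyond the scatter), which shows that this end can shift the number substantially, at least when the nitro group is present. Compound 3 is reported only as a limit, so the size of this step is a floor rather than an exact figure: the limit of > 100000 nM in this assay, at which 1 of the 4 values shown sits.

Ethoxycarbonyl appears here only with the nitro group, so it remains open whether the same change would have a similar effect with hydrogen or methyl on the phenyl ring. It is also unclear whether the added oxygen or the longer chain drives the step, a question that a propanoyl group or a carboxylic acid on the same carbonyl carbon could help to answer.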